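The source may hold more compounds than are shown below. What is called first, only, known or untested is meant among the compounds shown, and "the series" means these compounds.

Measured in a functional assay on A549 cells (Homo sapiens) for antiproliferative activity, read by MTT assay, with a stated time of 48 h; on this read-out lower numbers stand for stronger inhibition and higher numbers for weaker inhibition:
- compound 1 `Fc1ccc2[nH]c(-c3cn(-c4ccccc4)nc3-c3ccccc3)nc2c1`: 1720 nM
- compound 2 `Clc1cc2nc(-c3cn(-c4ccccc4)nc3-c3ccccc3)[nH]c2cc1Cl`: 11100 nM
- compound 3 `Fc1ccc(-c2nn(-c3ccccc3)cc2-c2nc3cc(F)ccc3[nH]2)cc1`: 1130 nM

Compound 3 and compound 1 lie within the scatter of each other, and compound 2 has the higher number by a margin beyond the scatter. The next compound is compound 4 `O=C(OCc1ccccc1)c1ccc2[nH]c(-c3cn(-c4ccccc4)nc3-c3ccc(F)cc3)nc2c1`, which carries benzyloxycarbonyl in place of fluoro on an aromatic carbon.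

For the measured compounds named here, only one measured step exists, a 1.5-fold lower number from compound 1 to compound 3 (0.18 log units; within the scatter), and it lies within the scatter. The fluoro that leaves here is present on both sides of that step, so the step says nothing direct about this change. The only other variation on the same ring is in compound 2 at 11100 nM, a single value from a different substitution, which offers a weak hint that changes on this ring may raise the number. Going by the values given here, no measured compound carries an ester, so the uncertainty is wide. A moderate move toward weaker inhibition is expected in this assay, estimated as a 2.2-fold higher number from compound 3 to compound 4 (0.34 log units; beyond the scatter). For compound 4 the estimated value is 2500 nM, with an expected range from 700 nM to 9000 nM.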

Compound 4, half-maximal inhibitory concentration: 21500 nM
Compound 4: middle estimate off by 8.6-fold (0.93 log units), on the low side, and the stated range ends below it.
By their numbers in this assay, from the lowest: compounds 3 and 1 (each within the scatter of the next); then compounds 2 and 4 (each within the scatter of the next).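

In this assay, benzyloxycarbonyl in place of fluoro on an aromatic carbon of the fused system of two rings gives a 19-fold higher number from compound 3 to compound 4 (1.28 log units; beyond the scatter) and is a large step, well beyond the scatter. The only earlier step, a 1.5-fold lower number from compound 1 to compound 3 (0.18 log units; within the scatter) and within the scatter, showed no measurable response to a substitution, so this is the first change in one place shown to move the number, and it shows that this position does not keep the level of compound 3 at 1130 nM when benzyloxycarbonyl enters. No measurement at hand explains the size of this step.

A carboxylic acid or a methyl ester at this place would help separate the contribution of the carbonyl from that of the benzyl part, while an amide would test whether the ester link itself matters. Also open, going by these compounds, is whether a small group such as methoxy or an amine would stay within the scatter of compound 3, and whether benzyloxycarbonyl would give a step of similar size on compound 1.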